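This account rests on a few compounds, and the source may have more. Where it says the series, first, only, none or still open, it means among the compounds named here.

Measured compounds:
compound 1 `COc1ccc(CNc2cc(OC)c(OC)c(OC)c2)cc1Cl` — 46200 nM
compound 2 `C=C(C)C(=O)N(Cc1ccc(OC)c(O)c1)c1cc(OC)c(OC)c(OC)c1` — 390 nM
compound 3 `COc1ccc(CNc2cc(OC)c(OC)c(OC)c2)cc1F` — 39700 nM

In a functional assay on MGC-803 cells (Homo sapiens) for inhibition, read by MTT assay, with a stated time of 48 h (a higher number here means a weaker inhibitor, a lower number a stronger inhibitor), compound 2 gives the lowest of the three numbers; compound 3 lies a 1.2-fold lower number from compound 1 to compound 3 (0.07 log units; within the scatter) step below compound 1, within the scatter, while compound 2 sits far below both, beyond the scatter. Within the data shown here, the only one-place step among the measured compounds, fluoro in place of chloro on an aromatic carbon, is the step from compound 1 to compound 3, and it is within the scatter.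

Compound 4 `COc1ccc(CN(C(=O)C[Se]C#N)c2cc(OC)c(OC)c(OC)c2)cc1O` differs from compound 2 as follows: a group of 4 heavy atoms (2 carbon, 1 nitrogen, 1 selenium; no ring) in place of a group of 3 heavy atoms (3 carbon; no ring), on a carbonyl carbon. Among the measured compounds shown here, the single measured step concerns a halogen on an aromatic carbon and says nothing about the acyl group on the amide-type nitrogen, so no measured step bears on this change. For the measured compounds named here, the gap between compound 3 and compound 2 shows only that their values differ by a large margin, not what an exchange on the carbonyl carbon does. With no guidance, the expected step from compound 2 to compound 4 is a 2.1-fold higher number from compound 2 to compound 4 (0.31 log units; beyond the scatter), with a wide range. Compound 4 is therefore estimated at 800 nM in this assay, between 150 nM and 5000 nM.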

Compound 4, half-maximal inhibitory concentration: 270 nM
The estimate for compound 4 lay 3.0-fold (0.47 log units) above the measured number, within the range that was stated.
By their numbers in this assay, from the lowest: compounds 4 and 2 (each within the scatter of the next); then compounds 3 and 1 (each within the scatter of the next).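

In this assay the first step measured on a carbonyl carbon whose other neighbour is the amide-type nitrogen is a 1.4-fold lower number from compound 2 to compound 4 (0.16 log units; within the scatter) and so gives no sign of a difference between 1-methylethenyl and the selenium-containing group of 4 heavy atoms. The earlier step concerned only a halogen on an aromatic carbon, whereas this one shows that the number at this position can hold through a larger exchange, in which a double bond gives way to a triple bond, selenium enters and the group gains a hydrogen-bond acceptor. Nothing available accounts for this agreement between the two groups.

The compounds shown leave open whether the agreement extends to other groups at this carbonyl carbon, such as a plain methyl, a longer chain or a sulfur atom in the place of selenium. They also leave open what the acyl group itself contributes, since no compound shown lacks it while keeping the rest of compound 2 unchanged.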